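The source may report more compounds than this note shows. Statements on the series, on what has been measured and on what is new or still open speak of the compounds shown alone.

Measured in a functional assay on SW480 cells (Homo sapiens) for antiproliferative activity, read by MTT assay, with a stated time of 48 h; on this read-out lower numbers stand for stronger inhibition and higher numbers for weaker inhibition:
Compound 1 `CCCCCC(CCO)n1cnc2c(N)ncnc21`: > 50000 nM (a limit)
Compound 2 `CCCCCCC(CCO)n1cnc2c(N(C)C)ncnc21`: > 50000 nM (a limit)

Neither compound has yielded a number in this assay. Compound 2 stands only at a limit, > 50000 nM, so its true position is not known. Compound 1 has a limit as well, > 50000 nM. The two compounds therefore share a single reading: the limit of > 50000 nM in this assay, at which 2 of the 2 values shown sit.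

The next compound, compound 3 `CCCCCCC(CCO)n1cnc2c(N)ncnc21`, departs from compound 2 in one place: amino in place of dimethylamino on an aromatic carbon. Amino takes the place of dimethylamino on an aromatic carbon of a six-membered aromatic ring with 2 nitrogen, part of a fused or bridged system of two rings.

Going by the values given here, no measured pair shows what this exchange does, so its size must be judged from the limit alone. Since compound 2 offers only > 50000 nM as a starting point, no change beyond the scatter is expected in this assay, and no direction is favoured. The expected move is a number no higher from compound 2 to compound 3 (the limit leaves the size open). For compound 3 the estimated value is 50000 nM, within an expected range of 25000 nM to 100000 nM.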

Compound 3, half-maximal inhibitory concentration: > 50000 nM
Compound 3: a limit, no number (the forecaster's own chance of this, stated with the estimate: 75%); the middle value sits exactly at the limit.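

In this assay compound 3 gives > 50000 nM as a limit, not a number. The steps to compound 3 from compound 1 and from compound 2 cannot be read, and all three compounds share one reading: the limit of > 50000 nM in this assay, at which 3 of the 3 values shown sit. Going by these compounds, what either exchange does to the activity stays open, as does the true position of each compound.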